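The compounds below may be only part of what the source reports. "The series", "measured", "known", "first", "only" and "open" are said of these compounds alone.

The series shares one core and varies only the aryl group on the amino nitrogen. In a functional assay on CWR22R cells (Homo sapiens) for inhibition, with a stated time of 120 h (a higher number here means a weaker inhibitor, a lower number a stronger inhibitor), compound 1 `Cc1n[nH]c2ccc(-c3nc4cnc(N5CCN(C)CC5)cn4c3Nc3cccc(Cl)c3)cc12` gives "not determined" (no result reported), and compound 2 `Cc1n[nH]c2ccc(-c3nc4cnc(N5CCN(C)CC5)cn4c3Nc3ccccc3)cc12` likewise gives "not determined" (no result reported); for both the entry holds no number. Within the data shown here, the only number in the set belongs to compound 3 `Cc1n[nH]c2ccc(-c3nc4cnc(N5CCN(C)CC5)cn4c3Nc3ccc(Cl)cc3F)cc12`: in this assay compound 3 gives 14100 nM, a weak result, and with the other two entries empty it stands alone, with nothing measured to compare against. Compound 4 `Cc1n[nH]c2ccc(-c3nc4cnc(N5CCN(C)CC5)cn4c3Nc3ccc(F)c(Cl)c3)cc12` is the next entry. The change from compound 3 is 3-chloro-4-fluorophenyl in place of 4-chloro-2-fluorophenyl on a nitrogen on an aromatic ring; the two compounds have the same atoms, joined differently, and the difference cut one bond further out reads (4-chloro-2-fluorophenyl)amino to (3-chloro-4-fluorophenyl)amino. Among the measured compounds shown here, no step between two measured compounds exists in this set, so no measured step can guide the size of this one. The change rearranges the same two halogens on the same ring without altering composition, and the expected step from compound 3 to compound 4 in this assay is a 1.2-fold lower number from compound 3 to compound 4 (0.07 log units; within the scatter), which is expected to stay within the scatter in either direction. Compound 4 is estimated at 12000 nM in this assay, with a range from 4000 nM to 40000 nM.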

Compound 4, half-maximal inhibitory concentration: 14000 nM
Estimate against measurement, compound 4: 1.2-fold (0.07 log units) below, and the stated range covers the measured number.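

In this assay, among these compounds, 3-chloro-4-fluorophenyl in place of 4-chloro-2-fluorophenyl on a nitrogen on an aromatic ring gives a 1.0-fold lower number from compound 3 to compound 4 (0.00 log units; within the scatter), the first step that can be read. Among the compounds shown here, with the same two halogens on the same ring, these two arrangements are not separated in this assay, something the single number for compound 3 could not show, though this rests on one pair and says nothing about other substitution patterns. No supporting measurement bears on this result, so the data offer no explanation for it.

Steps to compound 1 and compound 2 cannot be read, as neither entry holds a number, so the effect of either halogen alone, or of the unsubstituted phenyl, stays unknown in this assay. Also open, as far as these compounds go, is whether a different group on this aryl ring, such as a methoxy, a nitrile or a carboxylic acid, would move the number beyond the scatter from the level of compound 3 and compound 4.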